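The source may report more compounds than this note shows. Statements on the series, on what has been measured and on what is new or still open speak of the compounds shown alone.

Measured so far:
- compound 1, `C=C1C[C@]23C[C@@]1(O)CC[C@H]2c1ccc(O)c(C)c1[C@@H]3Cn1cc(-c2ccccn2)nn1`, in a functional assay on A549 cells (Homo sapiens) for cytotoxicity, read by MTT assay, with a stated time of 4 days; a higher number here means a weaker inhibitor, a lower number a stronger inhibitor: > 20000 nM
- compound 2, `C=C1C(=O)[C@]23C[C@@]1(O)CC[C@H]2c1ccc(OS(=O)(=O)c2ccc(C)cc2)c(C)c1[C@@H]3Cn1cc(-c2ccccn2)nn1`, in this assay: 2310 nM

Compound 1 gives only a limit in this assay: the value > 20000 nM is a limit of the assay and not a number, so compound 1 stands at the limit of > 20000 nM in this assay, at which 1 of the 2 values shown sits, without a measured strength. Within the data shown here, compound 2 gives a number in this assay, namely 2310 nM; no single-place step joins compound 2 to compound 1, and the two values show only that compound 2 reaches a number where compound 1 does not.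

Compound 3, `C=C1C[C@]23C[C@@]1(O)CC[C@H]2c1ccc(O)c(C)c1[C@@H]3Cn1cc(-c2ccc(Br)cc2)nn1`, differs from compound 1 in one place: 4-bromophenyl in place of pyridin-2-yl on an aromatic carbon. Among the measured compounds shown here, no measured step of this kind exists. The expected step in this assay is a number no higher from compound 1 to compound 3 (the limit leaves the size open), that is, none beyond the scatter, because compound 1 sits at the limit of > 20000 nM in this assay, at which 1 of the 2 values shown sits, and nothing measured points the way from there. Compound 3 is therefore estimated at 20000 nM in this assay, with a range from 7000 nM to 60000 nM, and a limit rather than a number is the more likely outcome.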

Compound 3, half-maximal inhibitory concentration: > 20000 nM
Compound 3 was reported as a limit; the forecaster's own chance of this, stated with the estimate: 60%; the middle value sits exactly at the limit.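

In this assay no step can be read between compound 1 and compound 3, because both stand at a limit of the assay and not at a number: the limit of > 20000 nM in this assay, at which 2 of the 3 values shown sit.

The compounds shown leave open how 4-bromophenyl and pyridin-2-yl compare on the shared core, as neither compound 1 nor compound 3 reaches a number in this assay.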